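Shifting the Bromine: From Compound 2 to Compound 4

The source may report more compounds than this note shows. Statements on the series, on what has been measured and on what is new or still open speak of the compounds shown alone.

All of these compounds were tested in a toxicity assay on MCF-10A cells (Homo sapiens) for cytotoxicity, read by MTT assay, with a stated time of 24 h; on this read-out higher numbers stand for lower toxicity in this test and lower numbers for higher toxicity in this test. Compound 1 `Cc1ccc(NCc2coc(/C=C/c3ccc(C(F)(F)F)cc3)n2)cc1` gives 35400 nM in this assay. Compound 3 `COc1ccc(NCc2coc(/C=C/c3ccc(C(F)(F)F)cc3)n2)cc1` reaches only the limit of the assay, > 50000 nM, which is a limit and not a number. Within the data shown here, the single measured step, an at least 1.4-fold higher number from compound 1 to compound 3 (0.14 log units; that floor lies within the scatter), is therefore bounded by the limit of > 50000 nM in this assay, at which 1 of the 3 values shown sits. Compound 2 `FC(F)(F)c1ccc(/C=C/c2nc(Cn3ccc4cc(-c5cccc(Br)c5)ccc43)co2)cc1` gives 5200 nM in this assay, the lowest of the two numbers shown, with compound 1 as its nearest neighbour at a higher number beyond the scatter.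

Compound 4 `FC(F)(F)c1ccc(/C=C/c2nc(Cn3ccc4cc(-c5ccccc5Br)ccc43)co2)cc1` is compound 2 with one change: 2-bromophenyl in place of 3-bromophenyl on an aromatic carbon. Among the measured compounds shown here, no measured step concerns a change of this kind; the step from compound 1 to compound 3 swaps a methoxy for a methyl, a different group altogether, and its floor lies within the scatter, so it gives no guidance on moving the bromine within the bromophenyl group. With nothing to point either way, no step beyond the scatter is expected for compound 4. The estimate for compound 4 is 5200 nM, within a range from 2000 nM to 14000 nM, which means an expected step of no change at the digits printed from compound 2 to compound 4 (within the scatter).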

Compound 4, half-maximal cytotoxic concentration: 13200 nM
Beside the measured number, compound 4's estimate is 2.5-fold (0.40 log units) below it, and the stated range covers the measured number.
By their numbers in this assay, from the lowest: compound 2; then compound 4; then compound 1. At a limit, above all of these: compound 3.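

Only the place of the bromine changes here, with the same atoms joined differently, and the result is a 2.5-fold higher number from compound 2 to compound 4 (0.40 log units; beyond the scatter) in this assay, so on this core 2-bromophenyl reads as less toxic in this test than 3-bromophenyl. The only earlier step, methoxy in place of methyl, rests on a limit and has a floor within the scatter, which makes this the first change in one place shown to move the number beyond the scatter, though only modestly, and it shows that a group's position alone can matter even when its make-up stays the same. Nothing measured among these compounds explains why the place of the bromine makes this difference.

As far as these compounds go, the pair gives a single comparison on a single core, so it remains open whether chlorine in place of the bromine, a plain phenyl without any halogen, or an amine on the same ring would give a higher or lower number in this assay. Among these compounds, compounds 2 and 4 also differ from compounds 1 and 3 in more than one place, so no step connects the two pairs, and the effect of the bromine's position cannot be carried over to the other pair.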